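Removing One Methoxy Group: Expected Paw Edema Inhibition

This account rests on a few compounds, and the source may have more. Where it says the series, first, only, none or still open, it means among the compounds named here.

Compound 1 `COc1ccc(-c2nnc(SCC(=O)c3ccccc3)n2-c2ccccc2)cc1OC`: 56%
Compound 2 `C=CCn1c(SCC(=O)c2ccccc2)nnc1-c1ccc(OC)c(OC)c1`: 61%
Compound 3 `CCn1c(SCC(=O)c2ccccc2)nnc1-c1ccc(OC)c(OC)c1`: 42%

All three compounds were tested in a functional assay on the whole organism (strain albino) for inhibition, with Rattus norvegicus as the target, read by paw edema, with a stated time of 1 h, at a dose of 0.28 mmol/kg by the oral route; on this read-out higher numbers stand for more inhibition at the one dose given (going by the name of the read-out) and lower numbers for less inhibition. Compound 1 holds the second highest of the three numbers. Its nearest neighbour is compound 2, with a number 5 percentage points higher from compound 1 to compound 2 (within the scatter), so the two cannot be told apart. Compound 3 lies furthest away, with a number 14 percentage points lower from compound 1 to compound 3 (beyond the scatter), and also a number 19 percentage points lower from compound 2 to compound 3 (beyond the scatter). Every one of these measured steps changes only the group attached to the aromatic nitrogen of the shared core.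

Compound 4 `COc1ccc(-c2nnc(SCC(=O)c3ccccc3)n2-c2ccccc2)cc1` differs from compound 1 in another place entirely: hydrogen in place of methoxy on an aromatic carbon. Going by the values given here, no measured step alters anything on that methoxy-bearing ring, so the measured steps give no direct guidance on the size or direction of this change. With nothing pointing either way, the expectation is a step that stays within the usual scatter of this assay, with the number for compound 4 staying close to that of compound 1.

The expected step is therefore a number 2 percentage points lower from compound 1 to compound 4 (within the scatter). The estimate for compound 4 is 54%, with a range from 38% to 70%.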

Compound 4, a percentage reported as inhibition, in the whole organism at one dose (the size of the read-out at that dose, not a potency): 52%
For compound 4 the middle estimate is 2 percentage points above the measured one, and the stated range covers the measured number.
By their numbers in this assay, from the lowest: compounds 3, 4, 1 and 2 (each within the scatter of the next, the first and the last beyond it).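

Going from 3,4-dimethoxyphenyl to 4-methoxyphenyl removes one methoxy group, and in this assay this gives a number 4 percentage points lower from compound 1 to compound 4 (within the scatter) and is the first view of any change on this ring. At this one dose, the methoxy group ortho to the other methoxy group can therefore be replaced by hydrogen with no difference that stands out from the scatter, whereas a change on the aromatic nitrogen can move the number beyond it, as in a number 19 percentage points lower from compound 2 to compound 3 (beyond the scatter) for the step from the allyl to the ethyl group. Nothing available bears on the reason for this result, so it stays a plain observation.

From the compounds shown here alone, what remains open is how this position responds to groups other than methoxy and hydrogen, such as a hydroxyl group, a chlorine atom or a longer ether like ethoxy. Going by these compounds, it is also open whether removing the remaining methoxy group to leave a plain phenyl would stay within the scatter, and whether the same removal would behave alike with the allyl group of compound 2 or the ethyl group of compound 3 on the nitrogen.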